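This account rests on a few compounds, and the source may have more. Where it says the series, first, only, none or still open, it means among the compounds named here.

Of the compounds shown here, three that share one core have been measured in a functional assay, with stated times of 30 s and 6 min, in the presence of a further agent that is not named here; a higher number here means a weaker inhibitor, a lower number a stronger inhibitor. Compound 1 `CCOc1cc(OC)c(Br)cc1C(C)=O` gives 37900000 nM, compound 2 `CCCCOc1cc(OC)c(Br)cc1C(C)=O` gives 38200000 nM, and compound 3 `CCCCCCCCOc1cc(OC)c(Br)cc1C(C)=O` gives 30900000 nM, which places compound 3 within the scatter of both others. Compound 4 `CCCCCCCCCCCCOc1cc(OC)c(Br)cc1C(C)=O` carries a longer chain than compound 3: butyl in place of hydrogen on a saturated chain carbon, eight bonds along the chain from an oxygen on an aromatic ring. The measured chain extensions bear on this change: a 1.0-fold higher number from compound 1 to compound 2 (0.00 log units; within the scatter), a 1.2-fold lower number from compound 2 to compound 3 (0.09 log units; within the scatter) and a 1.2-fold lower number from compound 1 to compound 3 (0.09 log units; within the scatter). All three are small and lie within the scatter, so no step beyond the scatter is expected in this assay. The step expected is a 1.1-fold higher number from compound 3 to compound 4 (0.03 log units; within the scatter). Compound 4 is estimated at 33000000 nM, with an expected range of 17000000 nM to 62000000 nM.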

Compound 4, half-maximal inhibitory concentration: 10600000 nM
Beside the measured number, compound 4's estimate is 3.1-fold (0.49 log units) above it; measured number below the stated range.
By their numbers in this assay, from the lowest: compound 4; then compounds 3, 1 and 2 (each within the scatter of the next).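

In this assay, for the compounds shown here, compound 4 gives the first steps beyond the scatter, with a 2.9-fold lower number from compound 3 to compound 4 (0.46 log units; beyond the scatter) and a 3.6-fold lower number from compound 2 to compound 4 (0.56 log units; beyond the scatter). Compounds 1, 2 and 3 lie within the scatter of one another, so among these four compounds a change at this oxygen-bound chain becomes visible only with the dodecyl chain of compound 4, where butyl replaces hydrogen eight bonds along the chain. Going by these compounds, whether a longer chain would lower the number further, or a chain ending in an amine or a carboxylic acid would do the same, remains open. No available evidence explains this step.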